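The source may report more compounds than this note shows. Statements on the series, on what has been measured and on what is new or still open speak of the compounds shown alone.

Compound 1 `N#Cc1ccc2c(F)cc(Oc3ccccc3OCCn3ccc(=O)[nH]c3=O)c(Cl)c2c1`, compound 2 `Cc1c(Oc2ccccc2OCCn2ccc(=O)[nH]c2=O)cc(F)c2ccc(C#N)cc12`, compound 3 `Cc1cc(Oc2ccccc2OCCn2ccc(=O)[nH]c2=O)c(Cl)c2cc(C#N)ccc12` and compound 4 `Cc1cc(Oc2ccccc2OCCn2ccc(=O)[nH]c2=O)c(C)c2cc(C#N)ccc12` share one core and differ only in the small groups on the fused ring. In a toxicity assay on MT2 cells (Homo sapiens) for cytotoxicity, read by MTT assay (a higher number here means that more compound is tolerated, a lower number that less compound is tolerated), compound 1 gives > 100000 nM, which is a limit of the assay and not a number. In this assay compound 2 gives > 100000 nM, again a limit. In this assay compound 3 gives > 100000 nM, also a limit. The change from compound 1 to compound 2 is methyl in place of chloro on an aromatic carbon and the step it made is a step that the two limits leave unreadable from compound 1 to compound 2. The change from compound 1 to compound 3 is methyl in place of fluoro on an aromatic carbon and the step is a step that the two limits leave unreadable from compound 1 to compound 3. Neither step can be sized because of the limit of > 100000 nM in this assay, at which 3 of the 3 values shown sit. The change from compound 3 to compound 4 is methyl in place of chloro on an aromatic carbon; it is the same kind of change as that from compound 1 to compound 2, the place differing only in being para to a methyl group rather than para to a fluoro group. For compound 4 in this assay the expected step is a number no higher from compound 3 to compound 4 (the limit leaves the size open), an expectation resting on compound 3 sitting at the limit of > 100000 nM in this assay, at which 3 of the 3 values shown sit. Compound 4 is therefore estimated at 100000 nM, with a range from 40000 nM to 300000 nM, most probably reported again only as a limit.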

Compound 4, half-maximal cytotoxic concentration: > 100000 nM
Compound 4 ended at the assay's limit (the forecaster's own chance of this, stated with the estimate: 85%); the middle value lies on the limit itself.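

In this assay compound 4 gives > 100000 nM, a limit of the assay and not a number. Among these compounds, no step from compound 2 or compound 3 to compound 4 can be read: the limit of > 100000 nM in this assay, at which 4 of the 4 values shown sit. The compounds shown leave open whether any exchange of the small groups on the fused ring changes the tolerated concentration at all.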